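A Trifluoromethyl Step in a Cell Toxicity Test

A few compounds are considered here, and "the series" means these few. Any claim that something is new, unique, unknown or untested is made for them only; others in the source may bear on it.

Of the compounds shown here, two have so far been measured in an ADME assay on Vero cells (Chlorocebus sabaeus) for cytotoxicity, read by MTT assay, with a stated time of 96 h; on this read-out lower numbers stand for higher toxicity in this test and higher numbers for lower toxicity in this test. Compound 1 (`C/C(=N\NC(N)=O)c1ccc2c(c1)nc(-c1ccc(C(F)(F)F)cc1)n2C1CCCCC1`) gives > 100000 nM, and this is a limit of the assay, not a number. Among the compounds with values here, compound 2 (`C/C(=N\NC(N)=S)c1ccc2c(c1)nc(-c1ccccc1)n2C1CCCCC1`) gives 20000 nM, the only true number available, which makes it the single firm anchor for what follows.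

Compound 3 (`C/C(=N\NC(N)=S)c1ccc2c(c1)nc(-c1ccc(C(F)(F)F)cc1)n2C1CCCCC1`) is compound 2 with one change: trifluoromethyl in place of hydrogen on an aromatic carbon. Trifluoromethyl takes the place of hydrogen on an aromatic carbon, so phenyl becomes 4-(trifluoromethyl)phenyl. Within the data shown here, no measured pair isolates this change, so the data cannot show its size in this assay. The expectation is therefore a small step, not far beyond the usual scatter, leaning slightly towards higher numbers and so towards lower toxicity in this test. The reasoning starts from compound 2 at 20000 nM, and the range must stay wide with so little to go on. The estimated change is a 1.5-fold higher number from compound 2 to compound 3 (0.18 log units; within the scatter). Compound 3 is expected at 30000 nM, with an estimated range of 10000 nM to 90000 nM.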

Compound 3, half-maximal cytotoxic concentration: > 100000 nM
Compound 3: only a limit was reported; the forecaster's own chance of this, stated with the estimate: 20%; at least 3.3-fold (0.52 log units) between middle value and limit.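

The change from phenyl to 4-(trifluoromethyl)phenyl now has a measured pair, and in this assay it gives an at least 5.0-fold higher number from compound 2 to compound 3 (0.69 log units; beyond the scatter) in the direction of lower toxicity in this test. On these data alone, the value of compound 3 is a limit of the assay and not a number, and the full size of this step stays unknown because of where that value sits: the limit of > 100000 nM in this assay, at which 2 of the 3 values shown sit. Compound 1 and compound 3 differ by oxygen against sulfur in the side chain, but both their values are limits, so the step between them cannot be read.

The compounds shown hold only one group other than hydrogen on this aromatic carbon, so it remains open whether a single fluorine atom, a methoxy group or an amine in the same place would also shift the number in this assay, or whether this shift belongs to trifluoromethyl alone. As far as these compounds go, it is also open how far the change carries over to other cores or side chains, such as a compound with oxygen in the side chain and plain phenyl on the core, which would show what sulfur does without trifluoromethyl present.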